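Swapping the hydroxy for a triazole on the cyclohexyl ring

The source may hold more compounds than are shown below. What is called first, only, known or untested is meant among the compounds shown, and "the series" means these compounds.

Compound 1 `N#Cc1cnc(NCc2cnccc2C(F)(F)F)cc1N[C@H]1CC[C@@H](O)CC1` gives 4500 nM in an assay on isolated protein for inhibition of protein kinase C delta type (Homo sapiens), read by TR-FRET, with a stated time of 2 h; a higher number here means a weaker inhibitor, a lower number a stronger inhibitor.
Compound 3 `N#Cc1cnc(NCc2cnccc2C(F)(F)F)cc1NCC1CCOCC1` gives 5000 nM in this assay.
Compound 2 `CO[C@H]1CC[C@H](CNc2cc(NCc3cnccc3C(F)(F)F)ncc2C#N)CC1` is reported in this assay only as a limit, > 10000 nM.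

Compound 1 has the lowest of the two numbers, and compound 3 sits close to it: a 1.1-fold higher number from compound 1 to compound 3 (0.05 log units; within the scatter). Compound 4 `N#Cc1cnc(NCc2cnccc2C(F)(F)F)cc1N[C@H]1CC[C@@H](n2cncn2)CC1` differs from compound 1 by 1H-1,2,4-triazol-1-yl in place of hydroxy on a saturated ring carbon. The measured step that bears most on this change is the loss of the hydroxy group in an at least 2.2-fold higher number from compound 1 to compound 2 (0.34 log units; beyond the scatter), though that step also inserted an extra carbon. A modest weakening is therefore expected, a 1.8-fold higher number from compound 1 to compound 4 (0.25 log units; within the scatter). Compound 4 is estimated to give 8000 nM in this assay, within a range of 3000 nM to 20000 nM.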

Compound 4, half-maximal inhibitory concentration: 5500 nM
The estimate for compound 4 lay 1.5-fold (0.16 log units) above the measured number; measured number inside the range.
By their numbers in this assay, from the lowest: compounds 1, 3 and 4 (each within the scatter of the next). At a limit, above all of these: compound 2.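

On the saturated ring carbon, 1H-1,2,4-triazol-1-yl, with five heavy atoms and no hydrogen-bond donor, can stand in place of hydroxy, with one heavy atom and one donor, and this assay shows a 1.2-fold higher number from compound 1 to compound 4 (0.09 log units; within the scatter). The numbers cannot be told apart, so a hydrogen-bond donor at this place is not required to keep this level of inhibition, and a far larger group is accepted here.

From the compounds shown here alone, whether an amine or a carboxylic acid on this ring carbon would move the number beyond the scatter stays open. Compound 2 offers no firm number for comparison, only a limit of the assay: the limit of > 10000 nM in this assay, at which 1 of the 4 values shown sits.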